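A few compounds are considered here, and "the series" means these few. Any claim that something is new, unique, unknown or untested is made for them only; others in the source may bear on it.

Measured compounds:
compound 1 `O=c1[nH]/c(=N\OCCCc2cccc(I)c2)ccn1[C@@H]1O[C@H](COP(=O)(O)OP(=O)(O)OP(=O)(O)O)[C@@H](O)[C@H]1O` — 325 nM
compound 2 `O=c1[nH]/c(=N\OCCCc2cccc([N+](=O)[O-])c2)ccn1[C@@H]1O[C@H](COP(=O)(O)OP(=O)(O)OP(=O)(O)O)[C@@H](O)[C@H]1O` — 457 nM
compound 3 `O=c1[nH]/c(=N\OCCCc2ccc([N+](=O)[O-])cc2)ccn1[C@@H]1O[C@H](COP(=O)(O)OP(=O)(O)OP(=O)(O)O)[C@@H](O)[C@H]1O` — 458 nM

In a functional assay on 1321-N1 cells for agonist activity at P2Y purinoceptor 2 (Homo sapiens), read by scintillation counting and inositol phosphate accumulation (on this read-out higher numbers stand for an effect only at larger amounts of compound and lower numbers for an effect already at smaller amounts), compound 3 holds the highest of the three numbers, yet its gaps to the others, a 1.0-fold higher number from compound 2 to compound 3 (0.00 log units; within the scatter) and a 1.4-fold higher number from compound 1 to compound 3 (0.15 log units; within the scatter), both lie within the scatter, so no order among the three can be claimed. Compound 4 `O=c1[nH]/c(=N\OCCCc2cccnc2)ccn1[C@@H]1O[C@H](COP(=O)(O)OP(=O)(O)OP(=O)(O)O)[C@@H](O)[C@H]1O` differs from compound 3 by pyridin-3-yl in place of 4-nitrophenyl on a saturated chain carbon, three bonds along the chain from an oxygen. Every measured step at this place, including a 1.4-fold higher number from compound 1 to compound 2 (0.15 log units; within the scatter), stayed within the scatter, so the step to the pyridin-3-yl group is expected to be small as well, and no direction beyond the scatter is expected: a 1.2-fold higher number from compound 3 to compound 4 (0.08 log units; within the scatter). Compound 4 is therefore estimated at 550 nM, with a range from 200 nM to 1600 nM.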

Compound 4, half-maximal effective concentration: 327 nM
Compound 4: middle estimate off by 1.7-fold (0.23 log units), on the high side; the measured number falls inside the stated range.
By their numbers in this assay, from the lowest: compounds 1, 4, 2 and 3 (each within the scatter of the next).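

In this assay the pyridin-3-yl group, with a hetero atom in its aromatic ring and no nitro or iodo substituent, stayed within the scatter of all three substituted phenyl groups (a 1.4-fold lower number from compound 3 to compound 4 (0.15 log units; within the scatter); a 1.4-fold lower number from compound 2 to compound 4 (0.15 log units; within the scatter); a 1.0-fold higher number from compound 1 to compound 4 (0.00 log units; within the scatter)). At this place, then, neither the ring hetero atom nor the loss of the substituent produced a step beyond the scatter. No evidence is available that would explain this result. The compounds shown leave open whether an amine, a carboxylic acid or a longer chain at this place would move the number beyond the scatter. They also leave open whether pyridin-2-yl or pyridin-4-yl would stay within it.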